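Hydroxy in place of propanoyl ester: stability expected to hold

The source may report more compounds than this note shows. Statements on the series, on what has been measured and on what is new or still open speak of the compounds shown alone.

The account follows a set of three measured compounds and one not yet measured. Compound 1 `CC(=O)OCOC(=O)C1=C(S[C@@H]2CN[C@H](C(=O)Nc3cccc(C(=O)OCOC(C)=O)c3)C2)[C@H](C)[C@@H]2[C@@H]([C@@H](C)O)C(=O)N12`, compound 2 `CCOC(=O)C1=C(S[C@@H]2CN[C@H](C(=O)Nc3cccc(C(=O)OCC)c3)C2)[C@H](C)[C@@H]2[C@@H]([C@@H](C)OC(=O)CC)C(=O)N12` and compound 3 `C[C@@H](O)[C@H]1C(=O)N2C(C(=O)OCOC(=O)C(C)(C)C)=C(S[C@@H]3CN[C@H](C(=O)Nc4cccc(C(=O)OCOC(=O)C(C)(C)C)c4)C3)[C@H](C)[C@H]12` share one core and differ in their ester and hydroxy groups. In a physicochemical assay for metabolic stability, read by LC-MS, in phosphate buffer, with a stated time of 3 h, at pH 7.4, tested at 50 uM (on this read-out lower numbers stand for a less stable compound and higher numbers for a more stable compound), compound 1 gives > 95%, which is a limit of the assay and not a number. In this assay compound 2 gives > 95%, again a limit. In this assay compound 3 gives > 95%, also a limit. Going by the values given here, compound 2 thus stands with the other two at the limit, as the limit of > 95% in this assay, at which 3 of the 3 values shown sit, records, and no step between measured compounds can be drawn.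

Compound 4 `CCOC(=O)C1=C(S[C@@H]2CN[C@H](C(=O)Nc3cccc(C(=O)OCC)c3)C2)[C@H](C)[C@@H]2[C@@H]([C@@H](C)O)C(=O)N12` differs from compound 2 by hydrogen in place of propanoyl on an oxygen on a saturated carbon. Compounds 1 and 3 carry the hydroxy in that place and sit at the limit, so no step beyond the scatter is expected here. Compound 4 is estimated at 95%, within 88% to 99%, and the expected step is a number no higher from compound 2 to compound 4 (the limit leaves the size open).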

Compound 4, percent of the compound remaining: > 95%
Compound 4: no number, only a limit; the forecaster's own chance of this, stated with the estimate: 80%; the middle value sits exactly at the limit.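

No step from compound 2 to compound 4 can be read in this assay, because both compounds give a limit and not a number: the limit of > 95% in this assay, at which 4 of the 4 values shown sit.

The compounds shown leave open whether propanoyloxy and hydroxy, or the different ester groups, make any difference in this assay.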